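A 1H-benzimidazol-2-yl analogue of compound 1

The compounds below may be only part of what the source reports. "The series", "measured", "known", "first", "only" and "open" are said of these compounds alone.

Going by the values given here, in an ADME assay on microsomes from liver (Rattus norvegicus) for metabolic stability, read by LC-MS, with a stated time of 10 min, tested at 0.5 uM (on this read-out higher numbers stand for a more stable compound and lower numbers for a less stable compound), compound 1 `c1ccc2c(c1)CN[C@@H](CN(CCCN1CCNCC1)[C@H]1CCCc3cccnc31)C2` gives 100%, the higher of the two numbers so far, while compound 2 `c1ccc2c(c1)CN[C@@H](CN(CC[C@@H]1CCCNC1)[C@H]1CCCc3cccnc31)C2` gives 28%. Among the compounds with values here, the only measured step is a number 72 percentage points lower from compound 1 to compound 2 (beyond the scatter), and it places piperidin-3-yl in place of (piperazin-1-yl)methyl on a saturated chain carbon. Compound 3 `c1cnc2c(c1)CCC[C@@H]2N(CCCN1CCNCC1)Cc1nc2ccccc2[nH]1` keeps the (piperazin-1-yl)methyl group of compound 1 and changes a different place: 1H-benzimidazol-2-yl in place of 1,2,3,4-tetrahydroisoquinolin-3-yl on a saturated chain carbon bound to an amine nitrogen. Within the data shown here, no measured step covers this exchange, so the data show only that one change in these compounds can be large. Since compound 1 stands at 100%, any clear movement is expected to be downward. The estimated step is a number 22 percentage points lower from compound 1 to compound 3 (beyond the scatter), smaller than the measured one, though this is uncertain. Compound 3 is estimated at 78%, with an expected range of 45% to 100%.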

Compound 3, percent of the compound remaining: 29%
Compound 3: middle estimate off by 49 percentage points, on the high side; measured number outside the range, below it.
By their numbers in this assay, from the lowest: compounds 2 and 3 (each within the scatter of the next); then compound 1.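

Replacing 1,2,3,4-tetrahydroisoquinolin-3-yl with 1H-benzimidazol-2-yl on a saturated chain carbon bound to an amine nitrogen gives a number 71 percentage points lower from compound 1 to compound 3 (beyond the scatter) in this assay, so a large step is now seen at a second place in these compounds. Keeping the (piperazin-1-yl)methyl group is therefore not enough on its own to hold the number at the level of compound 1. Nothing measured here bears on why the number falls at this place.

Going by these compounds, it remains open whether a 1H-indol-2-yl group or an open-chain primary amine at this place would stay closer to compound 1. Also open, on these data alone, is what the opposite stereocentre in the 1,2,3,4-tetrahydroisoquinolin-3-yl group would do, and whether piperidin-3-yl and 1H-benzimidazol-2-yl would act independently if combined in one structure.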